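Series notes: compound 1 and its 4-((methylsulfonyl)oxy)benzyl variant

This account rests on a few compounds, and the source may have more. Where it says the series, first, only, none or still open, it means among the compounds named here.

Measured so far:
compound 1 `O=C(CCCCCN1CCN(c2ccccc2-c2ccccc2)CC1)NCc1ccccc1` — 0.8 nM
compound 2 `COc1ccccc1N1CCN(CCCCCC(=O)NCc2ccccc2)CC1` — 224 nM

For the measured compounds named here, in an assay on HEK293 cells for displacement of a labelled ligand from 5-hydroxytryptamine receptor 7 (Rattus norvegicus) (on this read-out lower numbers stand for stronger inhibition and higher numbers for weaker inhibition), compound 1 gives the lowest of the two numbers; the nearest is compound 2, and the step of a 280-fold higher number from compound 1 to compound 2 (2.45 log units; beyond the scatter) is the only measured step in the set. That step concerns the aryl group on the piperazine side and says nothing about the benzyl end.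

Compound 3 `CS(=O)(=O)Oc1ccc(CNC(=O)CCCCCN2CCN(c3ccccc3-c3ccccc3)CC2)cc1` differs from compound 1 at that benzyl end: (methylsulfonyl)oxy in place of hydrogen on an aromatic carbon. Going by the values given here, no measured compound varies this position, so no step bears on it directly; the only guide is that compound 1 itself sits at 0.8 nM in this assay, leaving room on both sides.

Compound 3 is therefore expected to stay close to compound 1, with a step of a 1.9-fold higher number from compound 1 to compound 3 (0.27 log units; within the scatter) that is estimated to lie within or only slightly beyond the scatter. The estimate for compound 3 in this assay is 1.5 nM, range 0.4 nM to 6 nM.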

Compound 3, inhibition constant: 5.7 nM
The estimate for compound 3 lay 3.8-fold (0.58 log units) below the measured number; measured number inside the range.
By their numbers in this assay, from the lowest: compound 1; then compound 3; then compound 2.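

The benzyl end is not a silent position in this assay: (methylsulfonyl)oxy on the aromatic carbon, para to a large group, gives a real rise in the number (a 7.1-fold higher number from compound 1 to compound 3 (0.85 log units; beyond the scatter)). That group brings 5 heavy atoms and 3 hydrogen-bond acceptors, yet the step stays well short of the one on the piperazine side (a 280-fold higher number from compound 1 to compound 2 (2.45 log units; beyond the scatter)), and in this pair the position accepts a sizeable substituent at a modest cost. Nothing measured here bears on what lies behind the rise.

With only one substituent at this place, the step cannot be assigned to this particular group rather than to any group there; a hydroxyl, a methoxy or an amine on the same carbon would separate the two. On these data alone, whether the same change behaves alike on the methoxy compound 2 also remains open.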